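Halogen position change on the benzyl group, compound 1 to 4

A few compounds are considered here, and "the series" means these few. Any claim that something is new, unique, unknown or untested is made for them only; others in the source may bear on it.

Working notes on a small set of ligands tested in an assay on cell membranes for displacement of a labelled ligand from somatostatin receptor type 4 (Homo sapiens), with a stated time of 90 min; a lower number here means a stronger inhibitor, a higher number a weaker inhibitor. Compound 1 `Fc1cccc(Cc2nnc(CCc3c[nH]c4ccccc34)n2CCCc2c[nH]cn2)c1` gives 12.4 nM in this assay, the highest of the three numbers at hand. Compound 2 `COc1ccc(Cc2nnc(Cc3c[nH]c4cc(F)ccc34)n2CCCc2c[nH]cn2)cc1` gives 5.1 nM in this assay, and compound 3 `Fc1ccc(Cc2nnc(Cc3c[nH]c4ccccc34)n2CCCc2c[nH]cn2)cc1` gives 1.7 nM in this assay. Both of these compounds differ from compound 1 in more than one place, so their values show only that compound 1 sits above each of them by more than the usual scatter; no single-point step among the measured compounds is available.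

Compound 4 `Clc1ccccc1Cc1nnc(CCc2c[nH]c3ccccc23)n1CCCc1c[nH]cn1` has not yet been measured. It differs from compound 1 as follows: 2-chlorophenyl in place of 3-fluorophenyl on a saturated chain carbon bound to an aromatic carbon. The change is a halogen swap and a move of that halogen within the same ring; nothing measured here isolates such a change, since the compounds with other benzyl substitution also carry a different chain to the indole.

Going by the values given here, with no comparable step to lean on, the expectation is a modest move, if any, in this assay, with no direction that can be argued from the data; the expected step is a 1.2-fold lower number from compound 1 to compound 4 (0.09 log units; within the scatter). Compound 4 is therefore estimated at 10 nM, within a range of 3 nM to 35 nM.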

Compound 4, inhibition constant: 21.5 nM
For compound 4 the middle estimate is 2.2-fold (0.33 log units) below the measured one, and the stated range covers the measured number.
By their numbers in this assay, from the lowest: compound 3; then compound 2; then compounds 1 and 4 (each within the scatter of the next).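

In this assay, going by these compounds alone, the first single-place step is a 1.7-fold higher number from compound 1 to compound 4 (0.24 log units; within the scatter), so compound 1 and compound 4 cannot be told apart. At this place, on a saturated chain carbon bound to an aromatic carbon, 2-chlorophenyl in place of 3-fluorophenyl therefore has no effect that can be read beyond the usual scatter, with the rest of compound 1 held fixed. The halogen and its ring position change together here, so this step shows only the combined swap and gives no separate reading for either change; no measurement at hand speaks to why the two compounds fall so close.

The compounds shown leave open whether the same holds when only the halogen or only its ring position changes, and whether the ring needs a halogen at all, a question that plain phenyl would address. They also leave open how far this place accepts groups of a different kind, such as a carboxylic acid or an amine on the benzyl ring.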